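The source may report more compounds than this note shows. Statements on the series, on what has been measured and on what is new or still open speak of the compounds shown alone.

Measured compounds:
Compound 1, `COc1cccc(C(=O)NCCCNc2nc3cc(C)cc(C)c3cc2C#N)c1`, gives 4600 nM in an in vitro assay on FRT cells with Cystic fibrosis transmembrane conductance regulator variant F508del (Homo sapiens) as the target, read by fluorescence, with a stated time of 24 h, at 37 degrees C, in the presence of a further agent that is not named here; a lower number here means that less compound is needed, a higher number that more compound is needed for the effect.
Compound 2, `Cc1cc(C)c2cc(C#N)c(NCCCNC(=O)c3ccccn3)nc2c1`, is reported in this assay as "not active" (no number reported).

Compound 2 therefore stands without a single number on the half-maximal effective concentration scale: only compound 1 carries a measured value, and compound 2 is recorded as inactive under the same conditions. Compound 3, `Cc1cc(C)c2cc(C#N)c(NCCCNC(=O)c3ccncc3)nc2c1`, keeps the shared core and the three-carbon chain of compound 2 and differs only in the amide-bearing ring: pyridin-4-yl in place of pyridin-2-yl on a carbonyl carbon. Among the measured compounds shown here, because compound 2 is reported as "not active" (no number reported), no measured step exists from which the size of the change to compound 3 could be read; it can only be judged against compound 1, which shows that a ring-substituted aroyl amide on this core can reach a measurable though weak value. The author expects compound 3 to land, if it gives a number at all, in the weak range near or beyond compound 1, with a substantial chance of again being reported without a value. The estimate for compound 3 in this assay is 9000 nM, within the range 2000 nM to 40000 nM.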

Compound 3, half-maximal effective concentration: 8200 nM
For compound 3 the middle estimate is 1.1-fold (0.04 log units) above the measured one; low and high end bracket the measured number.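

In this assay compound 3 gives 8200 nM with pyridin-4-yl on the carbonyl carbon, whereas compound 2, with pyridin-2-yl in the same place, has no number, so the two differ in outcome but the size of that difference cannot be read. Replacing 3-methoxyphenyl with pyridin-4-yl on a carbonyl carbon gives a 1.8-fold higher number from compound 1 to compound 3 (0.25 log units; within the scatter) and so does not separate the two groups in this assay, which shows that a pyridine amide on the shared core can give a value here. Nothing shown explains why the two pyridine amides differ.

The compounds shown leave open whether pyridin-3-yl on the same carbonyl carbon would give a number. They also leave open whether an amine on the ring, or a four-carbon chain in place of the three-carbon one, would change the value.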